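Swapping a sulfonamide for an isopropyl sulfone

The source may report more compounds than this note shows. Statements on the series, on what has been measured and on what is new or still open speak of the compounds shown alone.

Compound 1 `CCN(CC)C(=O)c1ccc(S(=O)(=O)N2CCC[C@@H](C(=O)N3CCN(c4nc(C(C)C)no4)CC3)C2)cc1`: in a functional assay on MIA PaCa-2 cells (Homo sapiens) for inhibition, read by MTT assay, with a stated time of 3 days (on this read-out lower numbers stand for stronger inhibition and higher numbers for weaker inhibition), compound 1 gives > 10000 nM, a limit of the assay and not a number.
Compound 2 `CC(C)c1noc(N2CCN(C(=O)[C@@H]3CCCN(S(=O)(=O)c4ccc(S(=O)(=O)NC(C)(C)C)cc4)C3)CC2)n1`: in this assay compound 2 gives > 10000 nM, likewise a limit and not a number.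

Compound 2 thus stands only at a limit, as does compound 1; their step that the two limits leave unreadable from compound 1 to compound 2 cannot be read, since (the limit of > 10000 nM in this assay, at which 2 of the 2 values shown sit). Compound 3 `CC(C)c1noc(N2CCN(C(=O)[C@@H]3CCCN(S(=O)(=O)c4ccc(S(=O)(=O)C(C)C)cc4)C3)CC2)n1` carries isopropyl in place of (tert-butyl)amino on a sulfonyl sulfur. Going by the values given here, no measured step bears on this change, so no direction can be inferred; with both known values at the limit, compound 3 is expected to sit near it too, a step that the limit leaves unreadable from compound 2 to compound 3, giving an estimate of 20000 nM with a range from 5000 nM to 80000 nM.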

Compound 3, half-maximal inhibitory concentration: > 10000 nM
Compound 3 ended at the assay's limit; the forecaster's own chance of this, stated with the estimate: 80%; the middle value does not contradict the limit.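

Going by these compounds alone, no step between compound 1, compound 2 and compound 3 can be read, because each value is a limit and not a number: the limit of > 10000 nM in this assay, at which 3 of the 3 values shown sit. From the compounds shown here alone, whether diethylcarbamoyl, (tert-butyl)sulfamoyl and isopropylsulfonyl differ at all in this assay stays open.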